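The compounds below may be only part of what the source reports. "The series", "measured", "known", "first", "only" and "open" are said of these compounds alone.

The measured compounds:

Compound 1 `O=S(=O)(Nc1ccc2oc(-c3ccccc3)nc2c1)c1ccccc1O` gives a result in an assay on isolated protein for inhibition of malate dehydrogenase, mitochondrial (Sus scrofa), with stated times of 45 min and 30 min (a lower number here means a stronger inhibitor, a higher number a weaker inhibitor), that is a limit of the assay, > 63000 nM.
Compound 2 `O=S(=O)(Nc1ccc(-c2nc3ccccc3o2)cc1)c1cccc(O)c1` gives in this assay a limit, > 63000 nM.
Compound 3 `CS(=O)(=O)Nc1ccc(-c2nc3ccccc3o2)cc1` gives in this assay a limit, > 63000 nM.

Compound 1 stands on no number at all: its value in this assay is only a limit, and the two further values shown are likewise limits, so no ordering among the three can be read. For the measured compounds named here, the one measured step, from compound 2 to compound 3, a step that the two limits leave unreadable from compound 2 to compound 3, swaps a methyl for a 3-hydroxyphenyl on the sulfonyl sulfur, yet both ends of that step sit at the limit, so its size cannot be read. That is the whole of the evidence on sulfonyl substituents, and it all rests at the limit of > 63000 nM in this assay, at which 3 of the 3 values shown sit.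

Compound 4 `Cc1ccc(S(=O)(=O)Nc2ccc3oc(-c4ccccc4)nc3c2)cc1` differs from compound 1 as follows: 4-methylphenyl in place of 2-hydroxyphenyl on a sulfonyl sulfur. Going by the values given here, no measured step bears directly on this exchange; the nearest, from compound 2 to compound 3, is unreadable. The expectation in this assay is therefore no step beyond the scatter, the step from compound 1 to compound 4 being estimated as a step that the limit leaves unreadable from compound 1 to compound 4. Compound 4 is expected to give about 100000 nM, in the range 30000 nM to 300000 nM, most likely reported again only as a limit.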

Compound 4, half-maximal inhibitory concentration: > 63000 nM
Compound 4: no number, only a limit; the forecaster's own chance of this, stated with the estimate: 85%; the middle value is on the limit's open side.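

In this assay compound 4 gives > 63000 nM as a limit and not a number. Compound 1 also gives only a limit, so no step can be read for 4-methylphenyl in place of 2-hydroxyphenyl between compound 1 and compound 4. The compounds shown leave open whether any sulfonyl substituent gives a readable value in this series: the limit of > 63000 nM in this assay, at which 4 of the 4 values shown sit.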